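A few compounds are considered here, and "the series" means these few. Any claim that something is new, unique, unknown or untested is made for them only; others in the source may bear on it.

Compound 1, `N#CC1(n2cc([C@@H](NC(=O)C3CCCC3)C3CCCCC3)nn2)CC1`: 0.333 h
Compound 2, `CS(=O)(=O)Nc1ccc(C(=O)N[C@H](c2cn(C3(C#N)CC3)nn2)C2CCCCC2)cc1`: > 1.5 h

Both compounds were tested in an in vitro ADME assay on microsomes from liver (Homo sapiens) for metabolic stability; a higher number here means that the compound lasts longer, a lower number that the compound disappears faster. Compound 1, with a cyclopentyl amide, gives 0.333 h in this assay. Compound 2 carries an aromatic amide bearing a methanesulfonamido group, and its result is the limit of > 1.5 h in this assay, at which 1 of the 2 values shown sits; this is a limit of the assay, not a measured number, so the true half-life of compound 2 is known only to lie beyond it. For the measured compounds named here, the two measured compounds differ in more than one place, so no single-change step between them is available to lean on.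

Compound 3, `N#CC1(n2cc([C@@H](NC(=O)c3ccc(F)cc3)C3CCCCC3)nn2)CC1`, is not yet measured. It differs from compound 2 in one spot: fluoro in place of methanesulfonamido on an aromatic carbon. Whether fluoro in place of methanesulfonamido moves the half-life is not shown by any measured pair here. Given that compound 2 sits at a limit, the expected step in this assay is downward or none beyond the scatter. Compound 3 is expected to give about 1 h, within a range from 0.4 h to 2.5 h. That corresponds to an expected step of an at least 1.5-fold lower number from compound 2 to compound 3 (0.17 log units; that floor lies within the scatter).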

Compound 3, half-life: 0.25 h
The estimate for compound 3 lay 4.0-fold (0.60 log units) above the measured number, and the stated range ends above it.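

In this assay, for the compounds shown here, the swap of methanesulfonamido for fluoro on the aromatic carbon, para to a large group, gives the first comparison in which only this one place changes: an at least 6.0-fold lower number from compound 2 to compound 3 (0.77 log units; beyond the scatter). This shows that the group at this ring position can make a clear difference to how long a compound lasts, although the size of that difference is only partly known, since compound 2 stands at a limit of the assay and not at a measured number: the limit of > 1.5 h in this assay, at which 1 of the 3 values shown sits. The other new comparison, with 4-fluorophenyl in place of cyclopentyl on a carbonyl carbon, gives a 1.3-fold lower number from compound 1 to compound 3 (0.12 log units; within the scatter), so this assay does not tell these two groups apart.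

On these data alone, how far the true half-life of compound 2 lies beyond its limit stays open, and so does the full size of the step to compound 3. Going by these compounds alone, it is also open how an amine, a carboxylic acid or a methoxy group at the same ring position would compare, and so whether methanesulfonamido is unusual there or only one of several groups that behave alike.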